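This account rests on a few compounds, and the source may have more. Where it says the series, first, only, none or still open, it means among the compounds named here.

Measured so far in an ADME assay on microsomes from liver (Homo sapiens) for metabolic stability; a higher number here means faster removal of the compound, a lower number slower removal:
Compound 1 `CC(C)Oc1cc(Oc2ccc(S(C)(=O)=O)cc2)cc(-c2cncc(=O)[nH]2)c1` gives 11 mL/min/kg
Compound 2 `Cc1cnc(-c2cc(Oc3ccc(S(=O)(=O)N(C)C)cc3)cc(O[C@@H](C)CO)c2)[nH]c1=O` gives 12 mL/min/kg

Compound 2 stands level with compound 1, the two numbers lying within the usual scatter of each other. The next structure is compound 3 `CNS(=O)(=O)c1ccc(Oc2cc(O[C@@H](C)CO)cc(-c3ncc(C)c(=O)[nH]3)c2)cc1` and the change from compound 2 is a single one: hydrogen in place of methyl on a sulfonamide nitrogen with hydrogen in place of methyl on a sulfonamide nitrogen. Among the compounds with values here, no measured pair shows this change, so there is no direct precedent. Compound 1 at 11 mL/min/kg and compound 2 at 12 mL/min/kg differ in more than one place and still lie within the scatter, so the loss of one methyl is expected to shift little in this assay on this thin evidence. The estimated 1.2-fold lower number from compound 2 to compound 3 (0.08 log units; within the scatter) is expected to stay inside the scatter. For compound 3 the expected clearance is 10 mL/min/kg with an estimated range from 6 mL/min/kg to 17 mL/min/kg for the coming measurement.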

Compound 3, clearance in the Homo sapiens assay: < 8 mL/min/kg
Compound 3: only a limit was reported; the forecaster's own chance of this, stated with the estimate: 5%; middle value at least 1.2-fold (0.09 log units) away from the limit.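

Hydrogen in place of methyl on a sulfonamide nitrogen, dimethylsulfamoyl to methylsulfamoyl, now has its first single-place reading in the Homo sapiens assay, where compound 3 gives < 8 mL/min/kg, a limit of the assay: an at least 1.5-fold lower number from compound 2 to compound 3 (0.17 log units; that floor lies within the scatter). The change therefore gives no sign of faster removal at this position, though the floor of the step does not clear the scatter, and a real drop is not established. In a physicochemical assay for lipophilicity, using the shake flask method (a higher number here means a more lipophilic compound, a lower number a more polar compound), compound 2 gives 2.26 and compound 3 gives 2.01. In the physicochemical assay the same change gives a number 0.25 log units lower from compound 2 to compound 3 (within the scatter), so neither assay shows a step beyond the scatter.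

From the compounds shown here alone, the true size of the step stays open because compound 3 is reported only as a limit of the assay: the limit of < 8 mL/min/kg in the Homo sapiens assay, at which 1 of the 3 values shown sits. Also open, going by these compounds, is how the series reads in the Homo sapiens assay with a primary sulfonamide, or with an ethyl or cyclopropyl group on that nitrogen.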